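The compounds below may be only part of what the source reports. "The series", "measured", "known", "first", "only" and "open" are said of these compounds alone.

Measured so far in a functional assay on Capan-2 cells (Homo sapiens) for inhibition, read by MTT assay, with a stated time of 72 h; a lower number here means a stronger inhibitor of growth, a higher number a weaker inhibitor of growth:
- compound 1, `CC(C)(C)c1ccc(CNCCCNS(=O)(=O)c2cc(C(F)(F)F)cc(C(F)(F)F)c2)cc1`, gives 2100 nM
- compound 2, `O=S(=O)(NCCCNCc1ccc(Cl)c(Cl)c1)c1cc(C(F)(F)F)cc(C(F)(F)F)c1`, gives 1800 nM
- compound 3, `O=S(=O)(NCCCNCc1ccc(C(F)(F)F)cc1)c1cc(C(F)(F)F)cc(C(F)(F)F)c1`, gives 2000 nM

Compound 3 stands second highest of the three numbers; its nearest neighbour is compound 1 a 1.1-fold lower number from compound 1 to compound 3 (0.02 log units; within the scatter), its furthest compound 2 a 1.1-fold higher number from compound 2 to compound 3 (0.05 log units; within the scatter), and neither gap exceeds the scatter. The next compound is compound 4, `O=S(=O)(NCCCNCc1ccccc1)c1cc(C(F)(F)F)cc(C(F)(F)F)c1`, which differs from compound 3 by hydrogen in place of trifluoromethyl on an aromatic carbon.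

Within the data shown here, two measured steps touch the same benzyl ring. The step from compound 1 to compound 3 exchanged one group on that aromatic carbon a 1.1-fold lower number from compound 1 to compound 3 (0.02 log units; within the scatter); the step from compound 2 to compound 3 exchanged the whole benzyl substitution pattern a 1.1-fold higher number from compound 2 to compound 3 (0.05 log units; within the scatter). Both stayed within the scatter, so the ring substituent so far has not moved the number in this assay. From the compounds shown here alone, removing it entirely is untested, but nothing here points to a shift beyond the scatter in either direction. Compound 4 is therefore expected near compound 3, with a 1.3-fold higher number from compound 3 to compound 4 (0.10 log units; within the scatter) as the estimated step, giving an expected 2500 nM within 1200 nM to 5500 nM.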

Compound 4, concentration for 50% growth inhibition: 14000 nM
Estimate against measurement, compound 4: 5.6-fold (0.75 log units) below, outside the stated range (above it).
By their numbers in this assay, from the lowest: compounds 2, 3 and 1 (each within the scatter of the next); then compound 4.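

In this assay the substituent on this benzyl ring does matter: hydrogen in place of trifluoromethyl gives a 7.0-fold higher number from compound 3 to compound 4 (0.85 log units; beyond the scatter) and hydrogen in place of tert-butyl gives a 6.7-fold higher number from compound 1 to compound 4 (0.82 log units; beyond the scatter) while phenyl in place of 3,4-dichlorophenyl gives a 7.8-fold higher number from compound 2 to compound 4 (0.89 log units; beyond the scatter) and all three steps lie beyond the scatter. The earlier compounds showed only that these three substituted rings could not be told apart; compound 4 shows that among these four compounds the bare phenyl stands apart, so having a substituent counts here more than which of the three it is. Nothing measured on these compounds gives a reason for this.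

The compounds shown leave open whether a single fluorine or a methyl on this aromatic carbon already brings the lower number back. Also open, from the compounds shown here alone, is whether removing the substituent costs as much with a longer chain in the shared core.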